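This account rests on a few compounds, and the source may have more. Where it says the series, first, only, none or still open, it means among the compounds named here.

Compound 1 `CC(=O)Nc1ccc(C2=NNC(=O)CC2)cc1`: 1 ug/mL in a functional assay for inhibition, with Homo sapiens as the target; a higher number here means that more compound is needed for the effect, a lower number that less compound is needed.
Compound 2 `O=C1CCC(c2ccc(NC(=O)CCl)cc2)=NN1`: 0.39 ug/mL in this assay.

Among the measured compounds shown here, compound 2 holds the lowest of the two numbers measured so far; its nearest neighbour is compound 1, and the step of a 2.6-fold lower number from compound 1 to compound 2 (0.41 log units; beyond the scatter) lies beyond the scatter. Compound 3 `O=C1CCC(c2ccc(NC(=O)CCCCl)cc2)=NN1` has not yet been measured. It differs from compound 2 by 2-chloroethyl in place of chloro on a saturated chain carbon bound to a carbonyl carbon. For the measured compounds named here, the only measured step, a 2.6-fold lower number from compound 1 to compound 2 (0.41 log units; beyond the scatter), concerns putting chloro onto this carbon in the first place, so it bears only loosely on the present change; no measured pair shows what lengthening the chain between carbonyl and chlorine does. A step close to the scatter in this assay is therefore expected, with a slight lean toward a higher number. Compound 3 is estimated at 0.6 ug/mL, within 0.2 ug/mL to 1.8 ug/mL, which means an expected step of a 1.5-fold higher number from compound 2 to compound 3 (0.19 log units; within the scatter).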

Compound 3, half-maximal effective concentration: > 46.4 ug/mL
Compound 3: no number, only a limit; the forecaster's own chance of this, stated with the estimate: 5%; at least 77-fold (1.88 log units) between middle value and limit.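

Putting 2-chloroethyl in place of chloro on a saturated chain carbon bound to a carbonyl carbon gives an at least 110-fold higher number from compound 2 to compound 3 (2.07 log units; beyond the scatter), so this place, which had so far shown only a modest step, can also produce a large one in this assay. Set against hydrogen at the same place, the change gives an at least 46-fold higher number from compound 1 to compound 3 (1.66 log units; beyond the scatter), so compound 2 and compound 3 both carry a chlorine yet fall on opposite sides of compound 1, and a chlorine in this chain is not enough by itself. Compound 3 gives only a limit of the assay, not a number: the limit of > 46.4 ug/mL in this assay, at which 1 of the 3 values shown sits.

The compounds shown cannot separate the effect of the longer chain from that of the chlorine at its end, which a plain propyl group at this place would do. Nor do they show how a chain of intermediate length, or an amine in place of the chlorine, would fare.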